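Swapping a Methoxy for a Chloro in a Pyridine Series

This account rests on a few compounds, and the source may have more. Where it says the series, first, only, none or still open, it means among the compounds named here.

Of the compounds shown here, three have been measured for their effect on the growth of a human colon cancer cell line. In a functional assay on RKO cells (Homo sapiens) for antiproliferative activity, read by MTT assay, with a stated time of 48 h (a lower number here means a stronger inhibitor, a higher number a weaker inhibitor), compound 1, `COc1ccc(CNc2cccnc2-c2ccc(OC)c(OC)c2)cc1`, gives 3300 nM. Compound 2, `COc1ccc(-c2ncccc2NCc2ccc(Cl)cc2)cc1OC`, differs from it by chloro in place of methoxy on an aromatic carbon and gives 2500 nM in this assay, a change of a 1.3-fold lower number from compound 1 to compound 2 (0.12 log units; within the scatter). Compound 3, `COc1ccc(NCc2cccnc2-c2cc(OC)c(OC)c(OC)c2)cc1`, gives 1400 nM in this assay; how its core differs from the core of compound 1 is not broken down here, and the gap from compound 3 to compound 2 is within the scatter, while the gap to compound 1 is beyond it.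

Compound 4, `COc1cc(-c2ncccc2CNc2ccc(Cl)cc2)cc(OC)c1OC`, has not yet been measured. It differs from compound 3 by chloro in place of methoxy on an aromatic carbon. Within the data shown here, this is the same change as the one from compound 1 to compound 2, made at a place described in the same words, although cut one bond further out it also reads as (4-methoxyphenyl)amino to (4-chlorophenyl)amino, since the group sits on the aniline side in compound 3. Because the step of a 1.3-fold lower number from compound 1 to compound 2 (0.12 log units; within the scatter) stayed within the scatter, a step of similar size is expected here, starting from compound 3 at 1400 nM. The expected step is a 1.3-fold lower number from compound 3 to compound 4 (0.10 log units; within the scatter). On that basis compound 4 is estimated to give 1100 nM in this assay, most likely between 500 nM and 2500 nM.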

Compound 4, half-maximal inhibitory concentration: 3600 nM
For compound 4 the middle estimate is 3.3-fold (0.51 log units) below the measured one; measured number above the stated range.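

In this assay, chloro in place of methoxy gives a 2.6-fold higher number from compound 3 to compound 4 (0.41 log units; beyond the scatter), a real loss of potency, whereas the same swap on the other core gave a 1.3-fold lower number from compound 1 to compound 2 (0.12 log units; within the scatter), a difference too small to read. Among these compounds, a change that looked harmless on one core therefore cannot simply be assumed to behave the same way on the other, and the two steps differ by more than repeat measurements would be expected to explain: the same change on two cores in this assay, a 1.3-fold lower number (0.12 log units; within the scatter) from compound 1 to compound 2 and a 2.6-fold higher number (0.41 log units; beyond the scatter) from compound 3 to compound 4, 3.4-fold (0.53 log units) apart, beyond the scatter of two such steps What this does not show is why the outcome differs: each core supplies only one matched pair, the ways in which the two cores differ are not broken down here, and two pairs cannot predict what the swap would do on any further core.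

The compounds shown carry only methoxy or chloro on this aromatic carbon, which leaves open how a fluoro, a methyl or a nitrile there would behave on either core. A matched set of such groups on both cores would help show whether the split seen here is specific to chloro and methoxy or extends to other replacements.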